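Ethoxy homologue of compound 3 and its expected potency

The compounds below may be only part of what the source reports. "The series", "measured", "known", "first", "only" and "open" are said of these compounds alone.

Measured compounds in a functional assay on CHO-K1 cells for antagonist activity at C-X-C chemokine receptor type 3 (Homo sapiens), read by FLIPR, with a stated time of 10 min; a lower number here means a stronger inhibitor, a higher number a weaker inhibitor:
compound 1, `Cc1ncc(-c2nc(C(F)(F)F)sc2N2CCN(C(=O)Cn3nc(C)nc3C)[C@H](C)C2)cn1`, gives 19 nM
compound 2, `CCc1ncc(-c2nc(C(F)(F)F)sc2N2CCN(C(=O)Cn3nc(C)nc3C)[C@H](C)C2)cn1`, gives 14 nM
compound 3, `COc1ccc(-c2nc(C(F)(F)F)sc2N2CCN(C(=O)Cn3nc(C)nc3C)[C@H](C)C2)cn1`, gives 18 nM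

Compound 2 differs from compound 1 by methyl in place of hydrogen on a saturated chain carbon bound to an aromatic carbon; the step of a 1.4-fold lower number from compound 1 to compound 2 (0.13 log units; within the scatter). Compound 3 carries another core, differing from compound 1 by 6-methoxypyridin-3-yl in place of 2-methylpyrimidin-5-yl on an aromatic carbon; the steps of a 1.1-fold lower number from compound 1 to compound 3 (0.02 log units; within the scatter) and a 1.3-fold higher number from compound 2 to compound 3 (0.11 log units; within the scatter) leave all three within the scatter of one another. Compound 4, `CCOc1ccc(-c2nc(C(F)(F)F)sc2N2CCN(C(=O)Cn3nc(C)nc3C)[C@H](C)C2)cn1`, not yet measured, differs from compound 3 by methyl in place of hydrogen on a saturated chain carbon bound to an oxygen on an aromatic ring. This is the same kind of change as from compound 1 to compound 2, but the place differs: there the chain carbon is bound to an aromatic carbon, here to an oxygen on an aromatic ring. Compound 4 is expected to show a 1.3-fold lower number from compound 3 to compound 4 (0.11 log units; within the scatter) in this assay, resting on compound 3 at 18 nM and the earlier step of a 1.4-fold lower number from compound 1 to compound 2 (0.13 log units; within the scatter). Compound 4 is estimated at 14 nM, between 7 nM and 30 nM.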

Compound 4, half-maximal inhibitory concentration: 8.8 nM
Compound 4: the middle estimate sits 1.6-fold (0.20 log units) above what was measured; the measured number falls inside the stated range.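

In this assay, the added methyl behaves alike on the two cores as far as these pairs can tell: the same change on two cores in this assay, a 1.4-fold lower number (0.13 log units; within the scatter) from compound 1 to compound 2 and a 2.0-fold lower number (0.31 log units; beyond the scatter) from compound 3 to compound 4, 1.5-fold (0.18 log units) apart, within the scatter of two such steps. This does not show that the change carries to any further core, and with a single pair per core it does not show that the step is larger on the methoxy-to-ethoxy side, even though a 2.0-fold lower number from compound 3 to compound 4 (0.31 log units; beyond the scatter) is beyond the scatter. Exchanging the aromatic group gives a 1.6-fold lower number from compound 2 to compound 4 (0.20 log units; within the scatter) for 6-ethoxypyridin-3-yl in place of 2-ethylpyrimidin-5-yl, and a 2.2-fold lower number from compound 1 to compound 4 (0.33 log units; beyond the scatter) for the same group in place of 2-methylpyrimidin-5-yl.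

Still open, going by these compounds, is how a longer chain, such as propoxy in place of the ethoxy of compound 4, would read. On these data alone, an amine at the end of that chain is equally open.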